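Side chain change from compound 3 to compound 4

The compounds below may be only part of what the source reports. "The series", "measured", "known", "first", "only" and "open" are said of these compounds alone.

In an ADME assay on L6 cells (Rattus norvegicus) for cytotoxicity (on this read-out higher numbers stand for weaker inhibition and lower numbers for stronger inhibition), compound 3 (`O=C(CN1CCCCC1)OC1CC2(N3CCCCC3)CC(c3ccccc3)C1C(c1ccccc1)C2`) gives 60400 nM. That lies within the scatter of compound 2 (`CN1CCN(CCC(=O)OC2CC3(N(C)C)CC(c4ccccc4)C2C(c2ccccc2)C3)CC1`) at 31100 nM, while compound 1 (`CN1CCN(CCC(=O)OC2CC3(N4CCCC4)CC(c4ccccc4)C2C(c2ccccc2)C3)CC1`) gives a lower number, 21300 nM, beyond the scatter.

The change to compound 4 (`CN1CCN(CCC(=O)OC2CC3(N4CCCCC4)CC(c4ccccc4)C2C(c2ccccc2)C3)CC1`) is (4-methylpiperazin-1-yl)methyl in place of piperidin-1-yl on a saturated chain carbon bound to a carbonyl carbon. Read one bond further out, 2-(4-methylpiperazin-1-yl)ethyl replaces (piperidin-1-yl)methyl. For the measured compounds named here, no measured step covers this change directly. Going by the values given here, the only measured step, a 1.5-fold higher number from compound 1 to compound 2 (0.16 log units; within the scatter), places dimethylamino in place of pyrrolidin-1-yl on a saturated ring carbon, and the 2-(4-methylpiperazin-1-yl)ethyl chain stays the same in both compounds. Compound 4 carries that same chain, so its number is expected to lie near those of compound 1 at 21300 nM and compound 2 at 31100 nM, lower than the number of compound 3. Among the compounds with values here, the expected size is a 2.3-fold lower number from compound 3 to compound 4 (0.37 log units; beyond the scatter), though this rests on only two compounds. For compound 4 the estimate is 26000 nM, with an expected range of 12000 nM to 55000 nM.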

Compound 4, half-maximal inhibitory concentration: 23500 nM
Beside the measured number, compound 4's estimate is 1.1-fold (0.04 log units) above it, and the stated range covers the measured number.
By their numbers in this assay, from the lowest: compounds 1, 4, 2 and 3 (each within the scatter of the next, the first and the last beyond it).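

In this assay, for the compounds shown here, (4-methylpiperazin-1-yl)methyl in place of piperidin-1-yl on a saturated chain carbon bound to a carbonyl carbon gives a 2.6-fold lower number from compound 3 to compound 4 (0.41 log units; beyond the scatter), the first step that isolates this side chain, with piperidin-1-yl held on the saturated ring carbon. With the 2-(4-methylpiperazin-1-yl)ethyl chain held, the ring-carbon amine reads a 1.3-fold lower number from compound 2 to compound 4 (0.12 log units; within the scatter) and a 1.1-fold higher number from compound 1 to compound 4 (0.04 log units; within the scatter), so dimethylamino, pyrrolidin-1-yl and piperidin-1-yl are not separated at that place. No evidence at hand accounts for the side-chain step.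

Compounds 3 and 4 differ in both the ring and the chain length, so the step cannot be assigned to either alone; a 2-(piperidin-1-yl)ethyl chain would separate the two. Also open, going by these compounds, is whether a morpholin-4-yl group on the saturated ring carbon would stay within this narrow spread.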